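The compounds below may be only part of what the source reports. "The series", "measured", "known", "first", "only" and "open" are said of these compounds alone.

Measured compounds:
- compound 1 `O=C(O)c1cn(C2CC2)c2cc(N3CCN(Cn4nc(-c5ccccc5O)n(Cc5ccccc5)c4=S)CC3)c(F)cc2c1=O`: in an ADME assay on HEK293 cells (Homo sapiens) for cytotoxicity, read by MTT assay, with a stated time of 72 h (on this read-out lower numbers stand for an effect already at smaller amounts and higher numbers for an effect only at larger amounts of compound), compound 1 gives 69100 nM
- compound 2 `O=C(O)c1cn(C2CC2)c2cc(N3CCN(Cn4nc(-c5cccc(O)c5)n(-c5ccccc5)c4=S)CC3)c(F)cc2c1=O`: in this assay compound 2 gives 140000 nM

Compound 2 stands at the higher of the two numbers in this assay; its nearest neighbour is compound 1, whose number is lower by a step that lies beyond the usual scatter. Both share the same core, and the two values show that compound 2 needs a larger amount than compound 1 before an effect on the cells appears.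

Compound 3 `COc1ccc(-n2c(-c3cccc(O)c3)nn(CN3CCN(c4cc5c(cc4F)c(=O)c(C(=O)O)cn5C4CC4)CC3)c2=S)cc1` has not yet been measured in this assay. It differs from compound 2 in one place: methoxy in place of hydrogen on an aromatic carbon — methoxy in place of hydrogen on an aromatic carbon, para to a large group. Among the compounds with values here, no measured pair here shows what a change of this kind does, so the expectation for compound 3 rests on the position of compound 2 alone. The step from compound 2 to compound 3 in this assay is expected to be small, most likely within the scatter, with the number for compound 3 estimated at 110000 nM (range 50000 nM to 250000 nM), which amounts to an expected step of a 1.3-fold lower number from compound 2 to compound 3 (0.10 log units; within the scatter).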

Compound 3, half-maximal effective concentration: 114000 nM
Compound 3: the middle estimate sits 1.0-fold (0.02 log units) below what was measured, and the stated range covers the measured number.
By their numbers in this assay, from the lowest: compounds 1, 3 and 2 (each within the scatter of the next, the first and the last beyond it).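

Replacing phenyl with 4-methoxyphenyl, at the place para to a large group on the six-membered aromatic ring, gives a 1.2-fold lower number from compound 2 to compound 3 (0.09 log units; within the scatter) in this assay. Within the data shown here, this is the first measured step at this position, and it shows that adding methoxy, with its 2 heavy atoms, 1 hydrogen-bond acceptor and no net charge, leaves the cell read-out of compound 3 indistinguishable from that of compound 2. Nothing measured here explains why the read-out holds steady through this change.

Going by these compounds, a single substituent at a single position says little about the position as a whole, so it remains open whether a different group there, such as an amine, a carboxylic acid or a longer chain like butoxy, would also leave the number within the scatter of compound 2. On these data alone, it is equally open whether methoxy would give the same result elsewhere on this ring, or whether the same change would behave alike on the closely related framework of compound 1.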